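Cytotoxicity notes: benzyl urea analogue of compound 2

The source may hold more compounds than are shown below. What is called first, only, known or untested is meant among the compounds shown, and "the series" means these compounds.

Within the data shown here, in an ADME assay on HEL cells (Homo sapiens) for cytotoxicity (a lower number here means that less compound is tolerated, a higher number that more compound is tolerated), compound 2 `COc1cc(NC(C)CCCNC(=O)NCc2ccncc2)c2ncccc2c1` gives 72000 nM, the only numerical value obtained so far. Compound 1 `COc1cc(NC(C)CCCNC(=O)NC(c2ccccc2)c2ccccc2)c2ncccc2c1` reaches only a limit of the assay, > 100000 nM; that limit is the limit of > 100000 nM in this assay, at which 1 of the 2 values shown sits. Among the measured compounds shown here, no step between two measured compounds is therefore available for comparison. Compound 3 `COc1cc(NC(C)CCCNC(=O)NCc2ccccc2)c2ncccc2c1` differs from compound 2 by phenyl in place of pyridin-4-yl on a saturated chain carbon bound to an amide-type nitrogen. For compound 3 a step of a 1.2-fold lower number from compound 2 to compound 3 (0.08 log units; within the scatter) is expected, which stays within the usual scatter of this assay and carries no clear direction. Compound 3 is accordingly estimated at 60000 nM, with a range from 25000 nM to 150000 nM.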

Compound 3, half-maximal cytotoxic concentration: 66000 nM
For compound 3 the middle estimate is 1.1-fold (0.04 log units) below the measured one; low and high end bracket the measured number.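

In this assay, phenyl in place of pyridin-4-yl on a saturated chain carbon bound to an amide-type nitrogen gives a 1.1-fold lower number from compound 2 to compound 3 (0.04 log units; within the scatter), so this exchange leaves no readable difference. Hydrogen in place of phenyl on the carbon bound to the amide-type nitrogen and an aromatic carbon gives an at least 1.5-fold lower number from compound 1 to compound 3 (0.18 log units; that floor lies within the scatter), which sets only a floor for that step. The number for compound 1 is a limit: the limit of > 100000 nM in this assay, at which 1 of the 3 values shown sits.

No readable step here goes beyond the scatter. Open, as far as these compounds go, is whether a piperidine, a carboxylic acid or a longer chain in place of benzyl would move the number beyond it.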